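Swapping the Methoxyphenyl Arm for a tert-Butyl Group

The compounds below may be only part of what the source reports. "The series", "measured", "known", "first", "only" and "open" are said of these compounds alone.

Compound 2 `COc1ccccc1-c1cc(-c2ccc(F)cc2)c(C#N)c(OC)n1`: 75 nM
Compound 1 `COc1cccc(-c2cc(-c3ccc(F)cc3)c(C#N)c(OC)n2)c1`: 108 nM

Both compounds were tested in an assay on isolated protein for inhibition of sulfide:quinone oxidoreductase, mitochondrial (Homo sapiens); a lower number here means a stronger inhibitor, a higher number a weaker inhibitor. Compound 2 has the lower of the two numbers, but the step of a 1.4-fold lower number from compound 1 to compound 2 (0.16 log units; within the scatter) lies within the scatter, so the two values cannot be told apart. That step only moves the methoxy group from one position of the phenyl ring to another; the ring itself stays in place.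

Compound 3 `COc1nc(C(C)(C)C)cc(-c2ccc(F)cc2)c1C#N` has not been measured. Its change from compound 2 is tert-butyl in place of 2-methoxyphenyl on an aromatic carbon. The measured step of a 1.4-fold lower number from compound 1 to compound 2 (0.16 log units; within the scatter) does not bear on this change: it compares two phenyl rings that differ in where the methoxy group sits, whereas here the whole ring leaves and a tert-butyl group without a ring enters. There is thus no measured guide for the size or direction of the step, and the expectation rests on the fact that a large part of the molecule is removed. Compound 3 is expected to give 250 nM, in a range from 50 nM to 1500 nM. The expected step of a 3.3-fold higher number from compound 2 to compound 3 (0.52 log units; beyond the scatter) is a moderate rise in number, with a wide range around it.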

Compound 3, half-maximal inhibitory concentration: 153 nM
Beside the measured number, compound 3's estimate is 1.6-fold (0.21 log units) above it, and the stated range covers the measured number.
By their numbers in this assay, from the lowest: compounds 2, 1 and 3 (each within the scatter of the next, the first and the last beyond it).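

Until now, only methoxyphenyl rings had been seen on this aromatic carbon next to the ring nitrogen; compound 3 shows that inhibition in this assay does not vanish when the whole ring and its oxygen are replaced by the smaller tert-butyl group, which has no ring. Measured against the 2-methoxyphenyl group, the change gives a 2.0-fold higher number from compound 2 to compound 3 (0.31 log units; beyond the scatter) and so costs only a modest amount, while against the 3-methoxyphenyl group it gives a 1.4-fold higher number from compound 1 to compound 3 (0.15 log units; within the scatter) and leaves two values that cannot be told apart. Nothing shown here explains why the numbers fall as they do.

What a smaller alkyl group such as methyl, a longer chain, an amine or a carboxylic acid would do on this carbon stays open, since tert-butyl is the only group without a ring among these compounds. From the compounds shown here alone, the 4-fluorophenyl group, the methoxy group and the cyano group are the same in all three compounds, so their share in these numbers also remains unknown.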